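The source may hold more compounds than are shown below. What is called first, only, known or untested is meant among the compounds shown, and "the series" means these compounds.

Measured compounds:
Compound 1 `C=CC[C@H]1C[C@]2([C@@H](C)Cc3ccc(OC)c(C)c3)OCOC2=CC1=O` gives 410 nM in a functional assay on M14 cells (Homo sapiens) for antiproliferative activity, with a stated time of 72 h; a higher number here means a weaker inhibitor, a lower number a stronger inhibitor.
Compound 2 `C=CC[C@H]1C[C@]2([C@@H](C)Cc3cc(C)c(OC)cc3F)OCOC2=CC1=O` gives 230 nM in this assay.

Compound 2 stands alongside compound 1 rather than apart from it: the step of a 1.8-fold lower number from compound 1 to compound 2 (0.25 log units; within the scatter) is within the scatter, so the two numbers cannot be told apart. The as yet unmeasured compound 3 `C=CC[C@H]1C[C@]2([C@@H](C)Cc3cc(NC(C)=O)c(OC)cc3F)OCOC2=CC1=O` differs from compound 2 in a single place: acetamido in place of methyl on an aromatic carbon. Going by the values given here, no measured step bears on this kind of change. Among the compounds with values here, the one step available, a 1.8-fold lower number from compound 1 to compound 2 (0.25 log units; within the scatter), concerns a fluoro in place of hydrogen elsewhere on the same ring and is itself within the scatter, so it says nothing about swapping a methyl for an acetamido. There is thus no measured ground for expecting a step in this assay beyond the scatter in either direction, and the estimate for compound 3 rests on compound 2 alone, with a wide range to reflect that. Compound 3 is expected to give about 400 nM in this assay, between 100 nM and 2000 nM. That estimate means an expected step of a 1.7-fold higher number from compound 2 to compound 3 (0.24 log units; within the scatter).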

Compound 3, half-maximal inhibitory concentration: 52 nM
For compound 3 the middle estimate is 7.7-fold (0.89 log units) above the measured one; measured number outside the range, below it.
By their numbers in this assay, from the lowest: compound 3; then compounds 2 and 1 (each within the scatter of the next).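

In this assay, going by these compounds alone, the step of a 4.4-fold lower number from compound 2 to compound 3 (0.65 log units; beyond the scatter) is the first in this short series to lie beyond the scatter, and it comes with acetamido in place of methyl on the aromatic carbon ortho to a methoxy group and para to a fluoro group. The earlier step concerned only a fluoro group in place of hydrogen and could not be told from the scatter, so it gave no sign that the number could move at all; this one shows that a change at this position can move it, and that here a larger group, bringing a hydrogen-bond donor and a hydrogen-bond acceptor that methyl lacks, lowers the number rather than raising it. Nothing given here tells why the number falls.

From the compounds shown here alone, only methyl and acetamido appear at this position, so it stays open whether a plain amine, a hydroxyl group or a longer amide such as propionamido would give a number like that of compound 3. Going by these compounds, it also stays open whether acetamido would give a similar step on the compound that lacks the fluoro group, compound 1.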